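The compounds below may be only part of what the source reports. "The series", "measured", "known", "first", "only" and "open" are said of these compounds alone.

Three close relatives share one core and differ only in a single halogen on the outer ring. Compound 1 `NC(=O)c1c(NC(=O)c2ccccc2Br)sc2c1CCN(C(=S)Nc1ccccc1Cl)C2` carries a chloro group there; in a functional assay on HeLa cells (Homo sapiens) for antiproliferative activity, with a stated time of 24 h (on this read-out higher numbers stand for weaker inhibition and lower numbers for stronger inhibition), compound 1 gives 46900 nM. Compound 2 `NC(=O)c1c(NC(=O)c2ccccc2Br)sc2c1CCN(C(=S)Nc1ccccc1F)C2` has fluoro in place of chloro. In this assay compound 2 gives > 50000 nM, which is a limit of the assay and not a number, as the limit of > 50000 nM in this assay, at which 1 of the 2 values shown sits, shows. Compound 2 therefore stands at the weak edge of what the numbers shown can tell. Within the data shown here, the only measured step, an at least 1.0-fold higher number from compound 1 to compound 2 (0.02 log units; that floor lies within the scatter), lies within the scatter. Compound 3 `NC(=O)c1c(NC(=O)c2ccccc2Br)sc2c1CCN(C(=S)Nc1ccccc1Br)C2` differs from compound 2 by bromo in place of fluoro on an aromatic carbon. Because the step of an at least 1.0-fold higher number from compound 1 to compound 2 (0.02 log units; that floor lies within the scatter) showed no movement beyond the scatter, none is expected here either, and compound 3 is estimated at an at least 1.1-fold lower number from compound 2 to compound 3 (0.04 log units; that floor lies within the scatter). In this assay compound 3 is expected to give 45000 nM, with a range from 20000 nM to 150000 nM.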

Compound 3, half-maximal inhibitory concentration: 24700 nM
Estimate against measurement, compound 3: 1.8-fold (0.26 log units) above, and the stated range covers the measured number.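

Bromo in place of fluoro gives an at least 2.0-fold lower number from compound 2 to compound 3 (0.30 log units; that floor lies within the scatter) and so has a higher floor than the earlier step at this position, though that floor still does not clear the scatter. In this assay compound 2 gives > 50000 nM as a limit of the assay and not a number, so the full size of that step cannot be read. Bromo in place of chloro gives a 1.9-fold lower number from compound 1 to compound 3 (0.28 log units; within the scatter) and so does not separate these two halogens on the 2-bromophenyl or 2-chlorophenyl ring.

The compounds shown leave open whether anything other than a halogen at this place would move the number beyond the scatter. A methoxy group, an amine or a carboxylic acid on the same ring would test this, as would a plain hydrogen in place of the halogen.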